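The source may report more compounds than this note shows. Statements on the series, on what has been measured and on what is new or still open speak of the compounds shown alone.

Measured so far:
- compound 1, `O=C(CCCCCCc1ccccc1)c1nc(C(F)(F)F)co1`: 214 nM
- compound 2, `CN(C)C(=O)c1coc(C(=O)CCCCCCc2ccccc2)n1`: 3390 nM
- compound 3, `CSc1coc(C(=O)CCCCCCc2ccccc2)n1`: > 10000 nM

In an assay on HEK-293T cells for inhibition of diacylglycerol lipase-alpha (Homo sapiens), read by colorimetric assay (a higher number here means a weaker inhibitor, a lower number a stronger inhibitor), compound 1 gives 214 nM and stands lowest of the three measured compounds. Compound 2 gives 3390 nM in this assay. For compound 3 this assay reports only a limit, > 10000 nM, so compound 3 holds the highest position among the measured compounds, with the limit of > 10000 nM in this assay, at which 1 of the 3 values shown sits, marking where it sits.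

The next compound, compound 4, `O=C(CCCCCCc1ccccc1)c1nc(-c2ccccn2)co1`, differs from compound 3 in one place: pyridin-2-yl in place of methylsulfanyl on an aromatic carbon. All three measured steps concern this same position of the shared core. a 16-fold higher number from compound 1 to compound 2 (1.20 log units; beyond the scatter). an at least 46-fold higher number from compound 1 to compound 3 (1.66 log units; beyond the scatter). an at least 2.9-fold higher number from compound 2 to compound 3 (0.46 log units; beyond the scatter). None of them introduces an aromatic ring at this position, so the size of the step to compound 4 cannot be read directly from them; what they do show is that this position sets the number over a wide span, and that compound 3 starts from the weakest end of it.

The expected step is therefore an at least 16-fold lower number from compound 3 to compound 4 (1.22 log units; beyond the scatter), toward a lower number, of a size that cannot be fixed closely from the measured compounds. The estimate for compound 4 in this assay is 600 nM, within the range 60 nM to 6000 nM.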

Compound 4, half-maximal inhibitory concentration: > 10000 nM
Compound 4: no number, only a limit; the forecaster's own chance of this, stated with the estimate: 15%; at least 16-fold (1.22 log units) between middle value and limit.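

In this assay compound 4 gives > 10000 nM, which is a limit of the assay and not a number. Pyridin-2-yl at this position therefore gives no readable value, any more than methylsulfanyl does, and the step between compound 3 and compound 4 cannot be read, so the two groups can only be placed together at the same limit: the limit of > 10000 nM in this assay, at which 2 of the 4 values shown sit.

Against the two compounds with readable values, the change gives an at least 2.9-fold higher number from compound 2 to compound 4 (0.46 log units; beyond the scatter) and an at least 46-fold higher number from compound 1 to compound 4 (1.66 log units; beyond the scatter), so a six-membered aromatic ring at this position, with its larger heavy-atom count, does not reach the level of dimethylcarbamoyl or trifluoromethyl in this assay.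

Going by these compounds, how far compound 3 and compound 4 lie beyond the limit remains open, and with it whether pyridin-2-yl and methylsulfanyl differ at all. Also open, on these data alone, is whether the ring nitrogen of pyridin-2-yl matters, which a plain phenyl or a pyridin-3-yl group at this position would test, and whether a nitrile or a pentafluoroethyl group would come closer to trifluoromethyl.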